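A few compounds are considered here, and "the series" means these few. Any claim that something is new, unique, unknown or untested is made for them only; others in the source may bear on it.

Compound 1 `O=c1[nH]cc(S(=O)(=O)Nc2ccc(-c3cn(-c4ccccc4)nn3)cc2)c(=O)[nH]1` gives 18000 nM in a functional assay on HepG2 cells (Homo sapiens) for antiproliferative activity, read by MTT assay, with a stated time of 24 h; a lower number here means a stronger inhibitor, a higher number a weaker inhibitor. Compound 2 `O=c1[nH]cc(S(=O)(=O)Nc2ccc(-c3cn(-c4cccc(F)c4)nn3)cc2)c(=O)[nH]1` returns only a limit of the assay in this assay, > 20000 nM. Compound 3 `O=c1[nH]cc(S(=O)(=O)Nc2ccc(-c3cn(-c4ccc(F)cc4)nn3)cc2)c(=O)[nH]1` likewise returns only a limit in this assay, > 20000 nM. Compound 3 therefore stands not on a number but on a limit, and (the limit of > 20000 nM in this assay, at which 2 of the 3 values shown sit). The steps of an at least 1.1-fold higher number from compound 1 to compound 2 (0.04 log units; that floor lies within the scatter) and an at least 1.1-fold higher number from compound 1 to compound 3 (0.04 log units; that floor lies within the scatter) show that fluoro in place of hydrogen on an aromatic carbon did not lower the number, while the step that the two limits leave unreadable from compound 2 to compound 3 cannot be sized from two limits. Compound 4 `O=c1[nH]cc(S(=O)(=O)Nc2ccc(-c3cn(-c4ccccc4Cl)nn3)cc2)c(=O)[nH]1` differs from compound 3 by 2-chlorophenyl in place of 4-fluorophenyl on an aromatic nitrogen. Going by the values given here, no measured step covers a chlorine on the ring that sits on the aromatic nitrogen, and every change at that ring so far has left the value at or near the limit. No movement beyond the scatter is therefore expected, so the step that the limit leaves unreadable from compound 3 to compound 4 is estimated to be small. Compound 4 is thus estimated at 25000 nM, with a range from 10000 nM to 60000 nM, and a further limit rather than a number is the more likely outcome.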

Compound 4, half-maximal inhibitory concentration: 2230 nM
Beside the measured number, compound 4's estimate is 11-fold (1.05 log units) above it; the measured number lies below the stated range.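

In this assay, the group on the aromatic nitrogen turns out to be able to move the value, which the fluorinated compounds had not shown: 2-chlorophenyl in place of 4-fluorophenyl gives an at least 8.9-fold lower number from compound 3 to compound 4 (0.95 log units; beyond the scatter) here, and in place of 3-fluorophenyl it gives an at least 8.9-fold lower number from compound 2 to compound 4 (0.95 log units; beyond the scatter) as well. Adding a chlorine to the ring on the aromatic nitrogen gives an 8.1-fold lower number from compound 1 to compound 4 (0.91 log units; beyond the scatter) in this series, whereas fluoro in the same kind of change did not lower the number. Compound 4 thus stands clear of the limit that holds compound 2 and compound 3: the limit of > 20000 nM in this assay, at which 2 of the 4 values shown sit.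

Both the halogen and its place on the ring differ between compound 4 and the fluorinated compounds, so the compounds shown do not separate the two. As far as these compounds go, how a 2-fluorophenyl, 4-chlorophenyl or 2-methoxyphenyl group would behave on the aromatic nitrogen remains open.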